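Benzylsulfanyl series: compound 3 awaiting measurement

A few compounds are considered here, and "the series" means these few. Any claim that something is new, unique, unknown or untested is made for them only; others in the source may bear on it.

Measured so far:
compound 1 `COc1ccc(C2N=C(SCc3ccccc3)NC(C)=C2C(=O)Nc2ccc(F)cc2)cc1OC`: 3.6%
compound 2 `COc1ccc(C2N=C(SCc3ccccc3Cl)NC(C)=C2C(=O)Nc2ccc(F)cc2)cc1OC`: 6.2%

In a functional assay on the whole organism (artery, strain albino) with Rattus norvegicus as the target, with a stated time of 30 min, at a dose of 10 mg/kg by the oral route (a higher number here means more inhibition at the dose given (going by the name of the read-out), a lower number less inhibition), compound 2 gives 6.2% and compound 1 gives 3.6%. Going by the values given here, the one step measured so far, a number 2.6 percentage points higher from compound 1 to compound 2 (within the scatter), does not separate the two beyond the scatter, so compound 2 stands level with compound 1 and neither can be called the higher of the pair.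

Compound 3 `COc1ccc(C2N=C(SCc3cccc(Cl)c3)NC(C)=C2C(=O)Nc2ccc(F)cc2)cc1OC` is the next unmeasured member. It differs from compound 2 as follows: 3-chlorophenyl in place of 2-chlorophenyl on a saturated chain carbon bound to a sulfur. The two have the same atoms, joined differently; the chlorophenyl that leaves and the chlorophenyl that enters match in every count given.

Among the compounds with values here, no measured step covers this kind of change. Within the data shown here, the only step available is the chloro-for-hydrogen change from compound 1 to compound 2, and it was small. With nothing pointing to a shift in either direction, the expected step of a number 0.2 percentage points lower from compound 2 to compound 3 (within the scatter) in this assay is none beyond the scatter. Compound 3 is therefore estimated at 6%, with a range of 0% to 15%.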

Compound 3, a percentage reported as inhibition, in the whole organism at one dose (the size of the read-out at that dose, not a potency): 5.2%
Compound 3: the middle estimate sits 0.8 percentage points above what was measured; low and high end bracket the measured number.
By their numbers in this assay, from the lowest: compounds 1, 3 and 2 (each within the scatter of the next).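

In this assay, placing the chlorine differently on the benzyl group, 3-chlorophenyl in place of 2-chlorophenyl on a saturated chain carbon bound to a sulfur, gives a number 1 percentage points lower from compound 2 to compound 3 (within the scatter), so this change of placement does not separate the two isomers. Read against the unsubstituted benzyl group, the 3-chlorobenzyl compound gives a number 1.6 percentage points higher from compound 1 to compound 3 (within the scatter), so the chloro-for-hydrogen change has now been seen at two placements on this ring, and neither result stands clear of the scatter: within these three compounds, this assay does not distinguish benzyl, 2-chlorobenzyl and 3-chlorobenzyl on the sulfur. No measurement beyond this single read-out is at hand to interpret the result.

Open, going by these compounds, is whether an amine or a carboxylic acid on that phenyl ring, or a longer chain in place of the benzyl group, would move the number beyond the scatter. Also open, on these data alone, is whether changes elsewhere on the shared core, such as replacing the methoxy groups or the fluoro group, would do so.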